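A few compounds are considered here, and "the series" means these few. Any claim that something is new, unique, unknown or untested is made for them only; others in the source may bear on it.

Working notes on the series. Compound 1 `O=C1C=C(Nc2ccccc2)C(=O)c2c1nc1n2[C@H]2OC[C@@H](O)[C@H]2OC1` carries an unsubstituted phenyl on the amine nitrogen, compound 2 `O=C1C=C(Nc2cccc(Cl)c2)C(=O)c2c1nc1n2[C@H]2OC[C@@H](O)[C@H]2OC1` a 3-chlorophenyl and compound 3 `O=C1C=C(Nc2ccc(Br)cc2)C(=O)c2c1nc1n2[C@H]2OC[C@@H](O)[C@H]2OC1` a 4-bromophenyl, all on the same core. In a functional assay on ECa-109 cells for inhibition, with ECa-109 cell line (Homo sapiens) as the target, read by sulforhodamine B assay (on this read-out lower numbers stand for stronger inhibition and higher numbers for weaker inhibition), compound 1 gives 4970 nM, compound 2 gives 4690 nM and compound 3 gives 2850 nM. Compound 3 has the lowest of the three numbers, yet both other compounds sit within the scatter of it: a 1.7-fold lower number from compound 1 to compound 3 (0.24 log units; within the scatter) and a 1.6-fold lower number from compound 2 to compound 3 (0.22 log units; within the scatter). The remaining step, a 1.1-fold lower number from compound 1 to compound 2 (0.03 log units; within the scatter), also stays within the scatter, so the three aryl groups cannot be told apart on these numbers.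

Compound 4 `COc1ccccc1NC1=CC(=O)c2nc3n(c2C1=O)[C@H]1OC[C@@H](O)[C@H]1OC3` is not yet measured. The change from compound 3 is 2-methoxyphenyl in place of 4-bromophenyl on an amine nitrogen. All three measured steps alter the aryl group on the amine nitrogen, and none of them moved the number beyond the scatter; the change to compound 4 is of the same kind, though the entering group has not been tried before. For compound 4 the expectation is therefore a 1.3-fold higher number from compound 3 to compound 4 (0.10 log units; within the scatter), with no movement beyond the scatter. Compound 4 is estimated at 3600 nM, in a range from 1500 nM to 9000 nM.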

Compound 4, half-maximal inhibitory concentration: > 4000 nM
Compound 4 was reported as a limit; the forecaster's own chance of this, stated with the estimate: 5%; middle value at least 1.1-fold (0.04 log units) from the limit.
By their numbers in this assay, from the lowest: compounds 3, 2 and 1 (each within the scatter of the next).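

In this assay compound 4 is reported only as a limit, > 4000 nM. Read against the exact number of the 4-bromophenyl compound, the change gives an at least 1.4-fold higher number from compound 3 to compound 4 (0.14 log units; that floor lies within the scatter), so the readable part of the step stays within the scatter, like the earlier aryl changes on the amine nitrogen, but unlike those steps it has no upper bound, and a larger step to 2-methoxyphenyl is not excluded. Among these compounds, the steps to compound 4 from compound 1 and compound 2 cannot be read, and this is the only value of its kind so far: the limit of > 4000 nM in this assay, at which 1 of the 4 values shown sits.

Whether 2-methoxyphenyl truly separates from the three other aryl groups therefore stays open, as the compounds shown give no number for compound 4 that could settle it. Also open is how the read-out responds to groups of a different kind on the amine nitrogen, such as a longer alkyl chain or a phenyl carrying a carboxylic acid, since all four compounds shown keep a phenyl ring there with at most one simple substituent.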